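Trimming One Ester From a Nucleoside Triester

A few compounds are considered here, and "the series" means these few. Any claim that something is new, unique, unknown or untested is made for them only; others in the source may bear on it.

Measured compounds:
compound 1, `COc1ncnc2c1ncn2[C@@H]1O[C@H](COC(=O)COc2ccccc2)[C@@H](OC(=O)COc2ccccc2)[C@@H]1OC(=O)COc1ccccc1`: 22000 nM
compound 2, `CCCCCCCC(=O)O[C@H]1[C@H](OC(=O)CCCCCCC)[C@@H](CO)O[C@H]1n1cnc2c(OC)ncnc21`: 36000 nM

Both compounds were tested in a physicochemical assay for solubility, in phosphate buffer; a higher number here means a more soluble compound, a lower number a less soluble compound. Compound 1 gives 22000 nM in this assay, and compound 2 gives 36000 nM; the gap between them is within the usual scatter, so neither stands apart from the other.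

Compound 3, `COc1ncnc2c1ncn2[C@@H]1O[C@H](CO)[C@@H](OC(=O)COc2ccccc2)[C@@H]1OC(=O)COc1ccccc1`, has not yet been measured. It comes from compound 1 by one change: hydrogen in place of (phenoxymethyl)carbonyl on an oxygen on a saturated carbon. Among the compounds with values here, no measured pair shows a change of this kind, so the size of its effect is not known from these data.

In this assay the step is expected to be a moderate increase in solubility, a 2.3-fold higher number from compound 1 to compound 3 (0.36 log units; beyond the scatter), although a result within the scatter would not surprise. On that basis compound 3 is estimated at 50000 nM, with a range from 20000 nM to 130000 nM.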

Compound 3, solubility: 67000 nM
The estimate for compound 3 lay 1.3-fold (0.13 log units) below the measured number, and the stated range covers the measured number.
By their numbers in this assay, from the lowest: compounds 1, 2 and 3 (each within the scatter of the next, the first and the last beyond it).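

In this assay, within the data shown here, hydrogen in place of (phenoxymethyl)carbonyl on this oxygen on a saturated carbon gives a 3.0-fold higher number from compound 1 to compound 3 (0.48 log units; beyond the scatter), the first step that can be read as a single change. It shows that losing one of the three esters, and the 10 heavy atoms that leave with it, moves the number beyond the usual scatter while the rest of compound 1 stays the same. No measurement here explains why the number rises.

The compounds shown leave open whether taking (phenoxymethyl)carbonyl off either of the other two oxygens would give a step of similar size. They also do not show whether a small acetyl ester on this oxygen, or an amine in place of the hydroxy, would give a number near compound 1 or near compound 3.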